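The compounds below may be only part of what the source reports. "The series", "measured", "known", "first", "only" and "open" are said of these compounds alone.

Measured compounds:
Compound 1 `COc1ccc(/C=N/NC(=O)c2cc([N+](=O)[O-])cc([N+](=O)[O-])c2)cc1`, which in a physicochemical assay for lipophilicity (on this read-out lower numbers stand for lower lipophilicity and higher numbers for higher lipophilicity), gives 3.08.
Compound 2 `COc1ccc(/C=N/NC(=O)c2ccc(OC)c(OC)c2)cc1`, which in this assay gives 3.39.
Compound 3 `COc1ccc(/C=N/NC(=O)c2cc([N+](=O)[O-])cc([N+](=O)[O-])c2)cc1OC`, which in this assay gives 2.83.

Compound 1 and compound 3 differ in one place only: methoxy in place of hydrogen on an aromatic carbon. In this assay this change gave a number 0.25 log units lower from compound 1 to compound 3 (within the scatter), so the two numbers cannot be told apart with confidence. Compound 2 has the highest of the three numbers, and its gaps to compound 1 and to compound 3 both lie beyond the scatter. How the core of compound 2 differs from the core of compound 1 is not broken down here.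

Compound 4 `COc1ccc(/C=N/NC(=O)c2ccc(OC)c(OC)c2)cc1OC` has not yet been measured in this assay. It stands to compound 2 exactly as compound 3 stands to compound 1: methoxy in place of hydrogen on an aromatic carbon. The surroundings of the change are the same in both pairs, so this is the same change made a second time. On the strength of compound 1 and compound 3, where the change gave a number 0.25 log units lower from compound 1 to compound 3 (within the scatter), the step from compound 2 to compound 4 is expected to be a number 0.25 log units lower from compound 2 to compound 4 (within the scatter). Compound 4 is therefore estimated at 3.14 in this assay, expected to fall between 2.85 and 3.45.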

Compound 4, partition coefficient: 2.42
Compound 4: middle estimate off by 0.72 log units, on the high side; the whole stated range lies above it.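

In this assay the same methoxy-for-hydrogen change gave a number 0.97 log units lower from compound 2 to compound 4 (beyond the scatter), whereas on the core of the first pair it gave a number 0.25 log units lower from compound 1 to compound 3 (within the scatter), so the size of the step seen on one core did not carry over to the other. Going by these compounds alone, the numbers go down in both pairs, but only the step on the core of compound 2 is clearly larger than repeat measurements would scatter, and two pairs are too few to show a rule for the series or to predict the step on a further core. Nothing shown here accounts for the difference between the two cores.

The compounds shown leave open how this change would behave on a third core, where the two steps shown would give little guidance. They also leave open what would happen in this assay if an amine, a carboxylic acid or a longer chain such as ethoxy stood at this place instead of methoxy.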